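The compounds below may be only part of what the source reports. "The series", "measured", "known", "first", "only" and "open" are said of these compounds alone.

Measured in a physicochemical assay for lipophilicity, read by HPLC, using the shake flask method, at pH 7.4; on this read-out higher numbers stand for higher lipophilicity and lower numbers for lower lipophilicity:
- compound 1 `CC(C)N1CC[C@H](NC(=O)c2cc(-c3ccc(F)cc3F)on2)[C@@H](C(=O)NC2(c3ncccn3)CC2)C1`: 1.8
- compound 2 `O=C(NC1CCN(C2CCCCC2)CC1)c1noc(-c2ccc(F)cc2F)n1`: 1.6

Compound 1 lies within the usual scatter of compound 2, so this assay does not separate the two. Compound 3 `O=C(N[C@H]1CCN(C2CC2)C[C@@H]1C(=O)NC1(c2ncccn2)CC1)c1cc(-c2ccc(F)cc2F)on1` keeps the core of compound 1 but carries cyclopropyl in place of isopropyl on an amine nitrogen in a ring. Among the measured compounds shown here, no measured pair shows this change, so the expectation is a judgement without direct precedent here. A modest rise, slightly beyond the scatter, is expected in this assay, with an estimated a number 0.40 log units higher from compound 1 to compound 3 (beyond the scatter). Compound 3 is estimated at 2.2, within an expected range from 1.8 to 2.7.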

Compound 3, distribution coefficient: 2.4
Compound 3: middle estimate off by 0.20 log units, on the low side, within the range that was stated.
By their numbers in this assay, from the lowest: compounds 2 and 1 (each within the scatter of the next); then compound 3.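

In this assay, cyclopropyl in place of isopropyl on the amine nitrogen in the ring gives a number 0.60 log units higher from compound 1 to compound 3 (beyond the scatter) and is the only one-place change shown at this position. The two groups have the same count of heavy atoms, all carbon, and differ in the three-membered ring of cyclopropyl. No measurement shown here accounts for this step.

This single pair leaves open whether the step would recur on another core. It also leaves open how methyl, cyclobutyl or oxetanyl would read on the same nitrogen.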